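Swapping 4-methylpiperazin-1-yl for chloro in compound 3

This account rests on a few compounds, and the source may have more. Where it says the series, first, only, none or still open, it means among the compounds named here.

In a functional assay on A549 cells (Homo sapiens) for inhibition, read by MTT assay, with a stated time of 72 h (a lower number here means a stronger inhibitor, a higher number a weaker inhibitor), compound 3 `CN1CCN(c2cc(C(=O)N3CCC4(CC3)CC(=O)c3nn(C(C)(C)C)cc3O4)c3ccccc3n2)CC1` has no exact number: its > 10000 nM is a limit of the assay. Compound 4 `CC(C)(C)n1cc2c(n1)C(=O)CC1(CCN(C(=O)c3cc(Cl)nc4ccccc34)CC1)O2` carries chloro in place of 4-methylpiperazin-1-yl on an aromatic carbon, next to the ring nitrogen (chloro in place of 4-methylpiperazin-1-yl on an aromatic carbon). Other groups have been measured on this same carbon. Compound 1 `CC(C)(C)n1cc2c(n1)C(=O)CC1(CCN(C(=O)c3cc(-c4ccc(N)cc4)nc4ccccc34)CC1)O2`, with 4-aminophenyl, gives 970 nM, and compound 2 `CC(C)(C)n1cc2c(n1)C(=O)CC1(CCN(C(=O)c3cc(-c4ccccn4)nc4ccccc34)CC1)O2`, with pyridin-2-yl, gives 7720 nM. Changing that group produced an 8.0-fold higher number from compound 1 to compound 2 (0.90 log units; beyond the scatter) and an at least 10-fold higher number from compound 1 to compound 3 (1.01 log units; beyond the scatter), yet only an at least 1.2-fold higher number from compound 2 to compound 3 (0.11 log units; that floor lies within the scatter). None of these steps involves chloro, so a step within the scatter, or a slightly lower number, is expected: an estimated at least 1.4-fold lower number from compound 3 to compound 4 (0.15 log units; that floor lies within the scatter). For compound 4 the expected value is 7000 nM, with an estimated range from 2500 nM to 20000 nM.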

Compound 4, half-maximal inhibitory concentration: 7170 nM
Estimate against measurement, compound 4: 1.0-fold (0.01 log units) below, and the stated range covers the measured number.
By their numbers in this assay, from the lowest: compound 1; then compounds 4 and 2 (each within the scatter of the next). At a limit, above all of these: compound 3.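

In this assay, chloro, a single atom with no ring, gives a number matching that of pyridin-2-yl on this carbon (a 1.1-fold lower number from compound 2 to compound 4 (0.03 log units; within the scatter)), while 4-aminophenyl remains clearly apart (a 7.4-fold higher number from compound 1 to compound 4 (0.87 log units; beyond the scatter)). Against 4-methylpiperazin-1-yl, only a floor can be read (an at least 1.3-fold lower number from compound 3 to compound 4 (0.14 log units; that floor lies within the scatter)). Compound 3 has only a limit of the assay, so the true size of that step stays unknown: the limit of > 10000 nM in this assay, at which 1 of the 4 values shown sits.

From the compounds shown here alone, whether a plain phenyl without the amine, or a small amine such as dimethylamino, would reach the lower number of compound 1 on this carbon stays open.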